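Para-methoxy on the benzyl amide of the stilbene-pyridyl series

The source may report more compounds than this note shows. Statements on the series, on what has been measured and on what is new or still open speak of the compounds shown alone.

Measured so far in a functional assay on A549 cells (Homo sapiens) for antiproliferative activity, read by CCK-8 assay, with a stated time of 48 h; a lower number here means a stronger inhibitor, a higher number a weaker inhibitor:
compound 1 `CNC(=O)c1cc(Oc2ccc(/C=C/c3ccccn3)cc2)ccn1`, 17400 nM
compound 2 `O=C(NCc1ccccc1)c1cc(Oc2ccc(/C=C/c3ccccn3)cc2)ccn1`, 18800 nM

Among the measured compounds shown here, compound 2 gives the highest of the two numbers, yet the only measured step, a 1.1-fold higher number from compound 1 to compound 2 (0.03 log units; within the scatter), is within the scatter, so no order between the two is claimed. Compound 3 `COc1ccc(CNC(=O)c2cc(Oc3ccc(/C=C/c4ccccn4)cc3)ccn2)cc1` differs from compound 2 by methoxy in place of hydrogen on an aromatic carbon. For the measured compounds named here, nothing measured bears directly on a methoxy group; the one step known, adding a phenyl to the amide chain, was flat. A step of a 1.1-fold lower number from compound 2 to compound 3 (0.04 log units; within the scatter) is therefore expected, none beyond the scatter. Compound 3 is estimated at 17000 nM, between 8000 nM and 40000 nM.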

Compound 3, half-maximal inhibitory concentration: 63600 nM
Estimate against measurement, compound 3: 3.7-fold (0.57 log units) below, and the stated range ends below it.
By their numbers in this assay, from the lowest: compounds 1 and 2 (each within the scatter of the next); then compound 3.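

In this assay the amide chain, flat so far, turns out to respond to a change on its phenyl ring: methoxy at the carbon para to a large group gives a 3.4-fold higher number from compound 2 to compound 3 (0.53 log units; beyond the scatter) and so weakens the compound. The 4-methoxyphenyl group also gives a 3.7-fold higher number from compound 1 to compound 3 (0.56 log units; beyond the scatter) while the plain phenyl stayed within the scatter, so the shift comes only with the methoxy present. No evidence in hand accounts for this shift.

Going by these compounds, it remains open whether a hydroxyl, a chlorine or an amine on the same carbon would act as methoxy does. A longer chain in place of the benzyl is equally untested in these compounds.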